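This account rests on a few compounds, and the source may have more. Where it says the series, first, only, none or still open, it means among the compounds named here.

Of the compounds shown here, three of a shared type have been tested in an ADME assay on MT4 cells (Homo sapiens) for activation, read by MTT assay; on this read-out higher numbers stand for lower toxicity in this test and lower numbers for higher toxicity in this test. Compound 1 has the structure `CCc1c(C(C)c2c(F)cccc2Cl)nc(SC(C)CC)[nH]c1=O`. In this assay compound 1 reaches only the limit > 3000 nM, which is a boundary of the test rather than a number. Compound 2, with the structure `CCCCSc1nc(C(C)c2c(F)cccc2Cl)c(CC)c(=O)[nH]1`, carries the change butyl in place of sec-butyl on a sulfur relative to compound 1. In this assay compound 2 likewise gives only the limit > 3000 nM. The step that the two limits leave unreadable from compound 1 to compound 2 therefore cannot be read, since both ends sit at the boundary.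

Compound 3 has the structure `CCC(C)Sc1nc(O)c(C)c(C(C)c2c(F)cccc2F)n1`. Its core differs from the core of compound 1, and the difference between the two cores is not broken down here. In this assay compound 3 also gives only the limit > 3000 nM. All three measured values thus share one feature, namely (the limit of > 3000 nM in this assay, at which 3 of the 3 values shown sit).

Compound 4, with the structure `CCCCSc1nc(O)c(C)c(C(C)c2c(F)cccc2F)n1`, has not yet been measured. It differs from compound 3 by the change (butyl in place of sec-butyl on a sulfur), the same change that leads from compound 1 to compound 2, at a place described in the same words. For compound 4 the step that the limit leaves unreadable from compound 3 to compound 4 is expected to be small, an expectation resting on compound 1 and compound 2 both sitting at the limit of > 3000 nM in this assay, at which 3 of the 3 values shown sit. In this assay compound 4 is therefore estimated at 5000 nM, with a range from 2500 nM to 20000 nM, and most likely the test will again report only its limit.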

Compound 4, half-maximal cytotoxic concentration: > 3000 nM
Compound 4 was reported as a limit; the forecaster's own chance of this, stated with the estimate: 85%; the middle value lies beyond the limit too.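

Compound 3 and compound 4 both give only a limit of the test in this assay, so the step between them cannot be read, and no new comparison arises: the limit of > 3000 nM in this assay, at which 4 of the 4 values shown sit. The compounds shown leave open how far any of the four lies from that limit, and whether butyl and sec-butyl on the sulfur differ at all in this test.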